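A few compounds are considered here, and "the series" means these few. Any claim that something is new, unique, unknown or untested is made for them only; others in the source may bear on it.

Compound 1 `COc1cc(/C=C/C(=O)c2cccc(-n3cc(-c4ccc(Cl)cc4)[nH]c3=O)c2)cc(OC)c1OC`: 10900 nM
Compound 2 `O=C(/C=C/c1cccc(O)c1)c1cccc(-n2cc(-c3ccccc3)[nH]c2=O)c1`: 5630 nM
Compound 3 `O=C(/C=C/c1cccc(O)c1)c1cccc(-n2cc(-c3ccc(Cl)cc3)[nH]c2=O)c1`: 3640 nM

In a functional assay on SK-MEL-28 cells (Homo sapiens) for inhibition (on this read-out higher numbers stand for weaker inhibition of growth and lower numbers for stronger inhibition of growth), compound 1 gives 10900 nM, the highest of the three numbers; compound 2 stands nearest to it, within the scatter, and compound 3 furthest, beyond the scatter. Compound 4 `COc1cc(/C=C/C(=O)c2cccc(-n3cc(-c4cc(OC)c(OC)c(OC)c4)[nH]c3=O)c2)cc(OC)c1OC` differs from compound 1 by 3,4,5-trimethoxyphenyl in place of 4-chlorophenyl on an aromatic carbon. Among the measured compounds shown here, the only measured step at this position is a 1.5-fold lower number from compound 2 to compound 3 (0.19 log units; within the scatter), which merely exchanges hydrogen for chloro and stays within the scatter. For the measured compounds named here, no measured pair removes chloro and brings in three methoxy groups, so the data offer no direction for this change, and compound 4 is expected to remain close to compound 1. Compound 4 is estimated at 12000 nM, within 4000 nM to 36000 nM. This amounts to an expected step of a 1.1-fold higher number from compound 1 to compound 4 (0.04 log units; within the scatter).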

Compound 4, concentration for 50% growth inhibition: 1610 nM
Estimate against measurement, compound 4: 7.5-fold (0.87 log units) above; the whole stated range lies above it.
By their numbers in this assay, from the lowest: compound 4; then compounds 3, 2 and 1 (each within the scatter of the next, the first and the last beyond it).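

In this assay, the group at this place on the five-membered aromatic ring can move the number beyond the scatter: with 3,4,5-trimethoxyphenyl in place of 4-chlorophenyl, the result is a 6.8-fold lower number from compound 1 to compound 4 (0.83 log units; beyond the scatter) in growth inhibition. The hydrogen-to-chloro step had stayed within the scatter, so this position had not yet shown such a response. Nothing measured here accounts for the step. The compounds shown leave open whether a single methoxy group would suffice, and whether a phenyl ring bearing an amine or a carboxylic acid would give a similar number.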